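This account rests on a few compounds, and the source may have more. Where it says the series, first, only, none or still open, it means among the compounds named here.

- compound 1 `O=C(c1ccc(Cl)cc1)N1CCC(NS(=O)(=O)c2cc(S(=O)(=O)c3ccccc3)ccc2C(F)(F)F)CC1` gives 3100 nM in a physicochemical assay for solubility; on this read-out lower numbers stand for lower solubility and higher numbers for higher solubility
- compound 2 `O=C(c1cccnc1)N1CCC(NS(=O)(=O)c2cc(S(=O)(=O)c3ccccc3)ccc2C(F)(F)F)CC1` gives 50000 nM
- compound 3 `O=C(O)c1ccc(N2CCC(NS(=O)(=O)c3cc(S(=O)(=O)c4ccccc4)ccc3C(F)(F)F)CC2)cc1` gives 25000 nM
- compound 4 `O=C(C1CCNCC1)N1CCC(NS(=O)(=O)c2cc(S(=O)(=O)c3ccccc3)ccc2C(F)(F)F)CC1` is not yet measured

Compound 3 and compound 2 lie within the scatter of each other, and both stand above compound 1 on these numbers. The next change puts (piperidin-4-yl)carbonyl in place of 4-carboxyphenyl on an amine nitrogen in a ring and gives compound 4. Going by the values given here, the steps that bear on it are the large 16-fold higher number from compound 1 to compound 2 (1.21 log units; beyond the scatter) and the modest 8.1-fold higher number from compound 1 to compound 3 (0.91 log units; beyond the scatter) together with a 2.0-fold lower number from compound 2 to compound 3 (0.30 log units; within the scatter) which lies within the scatter. Among the compounds with values here, no measured compound carries the entering group. A slight upward lean within the scatter is expected, the estimated move being a 1.6-fold higher number from compound 3 to compound 4 (0.20 log units; within the scatter) in this assay for now. Compound 4 is estimated at 40000 nM with an expected range of 15000 nM to 90000 nM as a working figure.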

Compound 4, solubility: 100000 nM
Compound 4: middle estimate off by 2.5-fold (0.40 log units), on the low side; measured number outside the range, above it.
By their numbers in this assay, from the lowest: compound 1; then compounds 3, 2 and 4 (each within the scatter of the next, the first and the last beyond it).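

On a carbonyl carbon, piperidin-4-yl, a non-aromatic ring, gives a 32-fold higher number from compound 1 to compound 4 (1.51 log units; beyond the scatter) in this assay and so replaces 4-chlorophenyl as pyridin-3-yl did, and a 2.0-fold higher number from compound 2 to compound 4 (0.30 log units; within the scatter) lies within the scatter, so an aromatic ring is not needed at this place for numbers of this size. Compound 4 separates from the 4-carboxyphenyl compound, with a 4.0-fold higher number from compound 3 to compound 4 (0.60 log units; beyond the scatter) beyond the scatter, although compound 2 and compound 3 do not separate. No measurement shown accounts for these steps.

As far as these compounds go, whether an open-chain amine on the carbonyl carbon would match piperidin-4-yl remains open. So does the effect of a methyl group on the ring nitrogen of piperidin-4-yl.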